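The source may report more compounds than this note shows. Statements on the series, on what has been measured and on what is new or still open speak of the compounds shown alone.

Measured compounds in an ADME assay on cells (Hepatocyte, Rattus norvegicus) for metabolic stability; on this read-out lower numbers stand for slow clearance and higher numbers for fast clearance:
Compound 1, `CN(C)C(=O)CN1CCC(c2cc3c(-c4ccc(=O)n(C5CCOCC5)c4)ccnc3[nH]2)CC1`, gives 2.3 uL/min.
Compound 2, `CC(C)n1cc(-c2ccnc3[nH]c(C4CCN(CC(=O)N(C)C)CC4)cc23)ccc1=O`, gives 2.3 uL/min.
Compound 3, `CN(C)C(=O)CN1CCC(c2cc3c(-c4ccc(=O)n(CC5CCOCC5)c4)ccnc3[nH]2)CC1`, gives 1.8 uL/min.

Compound 3 stands closest to compound 1, a 1.3-fold lower number from compound 1 to compound 3 (0.11 log units; within the scatter), and to compound 2, a 1.3-fold lower number from compound 2 to compound 3 (0.11 log units; within the scatter); neither gap exceeds the scatter, so the three compounds are not separated by this assay. Going by the values given here, the one remaining step, no change at the digits printed from compound 1 to compound 2 (within the scatter), likewise shows no change beyond the scatter.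

Compound 4, `CN(C)C(=O)CN1CCC(c2cc3c(-c4ccc(=O)n(C5CCC5)c4)ccnc3[nH]2)CC1`, has not yet been measured. It differs from compound 3 at one point: cyclobutyl in place of (oxan-4-yl)methyl on an aromatic nitrogen. Among the compounds with values here, the steps that bear on this change are those that swap the group on the same aromatic nitrogen: isopropyl for oxan-4-yl, (oxan-4-yl)methyl for oxan-4-yl, and (oxan-4-yl)methyl for isopropyl, and each of them sits within the scatter. Nothing measured here therefore points to a step in either direction for cyclobutyl. For compound 4 the expected step is a 1.2-fold higher number from compound 3 to compound 4 (0.09 log units; within the scatter), with no change beyond the scatter. Compound 4 is estimated at 2.2 uL/min, within a range from 1.2 uL/min to 4 uL/min.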

Compound 4, intrinsic clearance in a liver preparation (reported as CLH), per the amount of preparation that the assay uses in the Hepatocyte assay: 5.8 uL/min
Beside the measured number, compound 4's estimate is 2.6-fold (0.42 log units) below it, outside the stated range (above it).
By their numbers in the Hepatocyte assay, from the lowest: compounds 3, 1 and 2 (each within the scatter of the next); then compound 4.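

At this aromatic nitrogen, the Hepatocyte assay does respond to the group: a 3.2-fold higher number from compound 3 to compound 4 (0.51 log units; beyond the scatter) and a 2.5-fold higher number from compound 2 to compound 4 (0.40 log units; beyond the scatter) and a 2.5-fold higher number from compound 1 to compound 4 (0.40 log units; beyond the scatter) set cyclobutyl apart from all three earlier groups. Carbon-only groups do not sort together, for isopropyl in compound 2 stays level with the oxygen-bearing groups of compounds 1 and 3 while cyclobutyl does not. In a physicochemical assay for lipophilicity, using the shake flask method, measured as octanol-water partition, at pH 7.4 (a lower number here means a more polar compound, a higher number a more lipophilic compound), compound 3 gives 1.4 and compound 4 gives 1.9, so the step in clearance comes with a step in the distribution coefficient, though a single pair cannot tie the two together.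

From the compounds shown here alone, whether the two read-outs move together beyond this pair stays open. So does how a cyclopropyl or cyclopentyl group, or a hydroxyl on the cyclobutyl ring, would behave on this nitrogen.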